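From dimethylamino to trifluoromethoxy on the aromatic ring

The compounds below may be only part of what the source reports. "The series", "measured", "known", "first", "only" and "open" are said of these compounds alone.

Compound 1 (`CN(C)c1ccc(Nc2c(NCCCCCC(=O)NO)c(=O)c2=O)cc1`) gives 1400000 nM in a physicochemical assay for solubility, with a stated time of 24 h, tested at 30 mg/mL (a lower number here means a less soluble compound, a higher number a more soluble compound), while compound 2 (`C[C@H](CCCCC(=O)NO)Nc1c(Nc2ccc(N(C)C)cc2)c(=O)c1=O`) gives 27000000 nM and compound 3 (`C[C@@H](CCCCC(=O)NO)Nc1c(Nc2ccc(N(C)C)cc2)c(=O)c1=O`) gives 28000000 nM in the same test. Compound 2 thus shares the top of the series with compound 3 and stands well clear of compound 1. The measured steps are a 19-fold higher number from compound 1 to compound 2 (1.29 log units; beyond the scatter) and a 20-fold higher number from compound 1 to compound 3 (1.30 log units; beyond the scatter) for the added methyl on the chain, and a 1.0-fold higher number from compound 2 to compound 3 (0.02 log units; within the scatter) for configuration alone. Compound 4 (`C[C@H](CCCCC(=O)NO)Nc1c(Nc2ccc(OC(F)(F)F)cc2)c(=O)c1=O`) has trifluoromethoxy in place of dimethylamino on an aromatic carbon and keeps the rest of compound 2. Going by the values given here, none of the measured steps touches this group, so they give no direct guide. A moderate fall in this assay is expected on the structural change alone, smaller in size than a 19-fold higher number from compound 1 to compound 2 (1.29 log units; beyond the scatter) and uncertain. The expected change is a 4.5-fold lower number from compound 2 to compound 4 (0.65 log units; beyond the scatter) on this estimate. Compound 4 is estimated at 6000000 nM with a range of 1000000 nM to 25000000 nM for now.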

Compound 4, solubility: 70000000 nM
Estimate against measurement, compound 4: 12-fold (1.07 log units) below; measured number above the stated range.
By their numbers in this assay, from the lowest: compound 1; then compounds 2 and 3 (each within the scatter of the next); then compound 4.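

In this assay, going by these compounds alone, trifluoromethoxy in place of dimethylamino gives a 2.6-fold higher number from compound 2 to compound 4 (0.41 log units; beyond the scatter) at the aromatic carbon para to a large group, the first measured step at this position. The number therefore responds to this site as well as to the chain methyl, and dimethylamino is not required for a high reading with the chain methyl present. Nothing available bears on the reason for this rise. On these data alone, how a morpholine or a carboxylic acid would read on this aromatic carbon remains open. Also open, as far as these compounds go, is whether the step carries over to the chain of compound 1, which lacks the methyl.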